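Triazolylmethyl for aminomethyl on a thyroid peroxidase inhibitor

The compounds below may be only part of what the source reports. "The series", "measured", "known", "first", "only" and "open" are said of these compounds alone.

Compound 1 `CN(C)Cc1ccc(-n2cc(-c3ccc4cc[nH]c4c3)c3c(Cl)ccnc32)cc1`: 5300 nM in an assay on isolated protein for inhibition of thyroid peroxidase (Homo sapiens); a lower number here means a stronger inhibitor, a higher number a weaker inhibitor
Compound 2 `NCc1ccc(-n2cc(-c3ccc4cc[nH]c4c3)c(C(F)(F)F)n2)cc1`: > 30000 nM in this assay

Compound 2 shows only a limit of the assay, not a measured number. The limit of > 30000 nM in this assay, at which 1 of the 2 values shown sits, is all that is known of it. Compound 3 `FC(F)(F)c1nn(-c2ccc(Cc3nc[nH]n3)cc2)cc1-c1ccc2cc[nH]c2c1` carries 1H-1,2,4-triazol-3-yl in place of amino on a saturated chain carbon bound to an aromatic carbon. Among the measured compounds shown here, no measured step of this kind exists here. In this assay the step of an at least 1.2-fold lower number from compound 2 to compound 3 (0.07 log units; that floor lies within the scatter) is expected to be small, within the scatter or at most a modest gain. Compound 3 is estimated at 25000 nM, expected between 6000 nM and 60000 nM, with a real chance of another limit.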

Compound 3, half-maximal inhibitory concentration in the thyroid peroxidase assay: 5900 nM
Compound 3: the middle estimate sits 4.2-fold (0.63 log units) above what was measured; measured number outside the range, below it.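

In the thyroid peroxidase assay, compound 2 gives > 30000 nM, which is a limit of the assay and not a number. Putting 1H-1,2,4-triazol-3-yl in place of amino on this saturated chain carbon gives an at least 5.0-fold lower number from compound 2 to compound 3 (0.70 log units; beyond the scatter), so the position tolerates a ring and inhibition becomes measurable. In a physicochemical assay for solubility, at pH 6.8 (on this read-out higher numbers stand for higher solubility and lower numbers for lower solubility), compound 2 gives 62000 nM and compound 3 gives 11000 nM. In the physicochemical assay, the same change goes with lower solubility: the measured solubility of compound 2, 62000 nM, and of compound 3, 11000 nM, a 5.6-fold lower number (0.75 log units; beyond the scatter)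

This single pair cannot separate the effect of adding the ring from that of losing the amino group. As far as these compounds go, how a carboxylic acid or an amide on the same carbon would compare remains open.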